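A few compounds are considered here, and "the series" means these few. Any claim that something is new, unique, unknown or untested is made for them only; others in the source may bear on it.

Working notes on the series. Within the data shown here, in a functional assay on A549 cells (Homo sapiens) for antiproliferative activity, read by MTT assay, with a stated time of 48 h (a lower number here means a stronger inhibitor, a higher number a weaker inhibitor), compound 1 (`CNCC(=O)Nc1cc(OC)ccc1C(=O)c1cc(OC)c(OC)c(OC)c1`) gives 610 nM and compound 2 (`CCNCC(=O)Nc1cc(OC)ccc1C(=O)c1cc(OC)c(OC)c(OC)c1`) gives 750 nM, so compound 2 stands within the scatter of the only other measured number. The next structure is compound 3 (`COc1ccc(C(=O)c2cc(OC)c(OC)c(OC)c2)c(NC(=O)CN)c1`), and the change is hydrogen in place of ethyl on an amine nitrogen. Among the measured compounds shown here, one measured step bears on it: a 1.2-fold higher number from compound 1 to compound 2 (0.09 log units; within the scatter), which concerns the same group on that nitrogen and stays small. On these data alone, both measured compounds keep an alkyl group there, so the loss of that group altogether is untested and the range is kept wide. No shift beyond the scatter is expected in this assay, and no direction is favoured. The expected step is a 1.2-fold lower number from compound 2 to compound 3 (0.08 log units; within the scatter). The estimate for compound 3 is 620 nM, with an expected range of 230 nM to 1600 nM.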

Compound 3, half-maximal inhibitory concentration: 220 nM
Beside the measured number, compound 3's estimate is 2.8-fold (0.45 log units) above it; measured number outside the range, below it.
By their numbers in this assay, from the lowest: compound 3; then compounds 1 and 2 (each within the scatter of the next).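

In this assay, the amine nitrogen turns out not to be indifferent to its substituent: exchanging methyl and ethyl stays within the scatter (a 1.2-fold higher number from compound 1 to compound 2 (0.09 log units; within the scatter)), whereas hydrogen in place of ethyl (a 3.4-fold lower number from compound 2 to compound 3 (0.53 log units; beyond the scatter)) or of methyl (a 2.8-fold lower number from compound 1 to compound 3 (0.44 log units; beyond the scatter)) goes beyond it. The sensitivity therefore lies in having any alkyl group on that nitrogen rather than in which of these two it is, and compound 3, with its aminomethyl carbonyl group, gives the lowest number of the three, with both of its steps beyond the scatter. Nothing measured here accounts for this difference.

On these data alone, it remains open whether a longer chain such as propyl, or a branched group such as isopropyl, would match compounds 1 and 2. As far as these compounds go, the effect of a second methyl on the same nitrogen, as in a dimethylamino group, or of an acetyl group there, also remains open.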